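A few compounds are considered here, and "the series" means these few. Any claim that something is new, unique, unknown or untested is made for them only; others in the source may bear on it.

Measured compounds:

- compound 1, `CC(C)C(c1nnc[nH]1)c1ccc(-c2ccc3cccc(F)c3c2)[nH]c1=O`: 12 nM
- compound 2, `CC(C)C(c1ccc(-c2ccc3cccc(F)c3c2)[nH]c1=O)N1CCNC1=O`: 9.1 nM
- compound 3, `CC(C)C(c1noc(=O)[nH]1)c1ccc(-c2ccc3cccc(F)c3c2)[nH]c1=O`: 15 nM

The three compounds share one core and differ only in the group on a saturated chain carbon bound to an aromatic carbon and a saturated chain carbon. In an assay on CHO cells for displacement of a labelled ligand from prostaglandin E2 receptor EP3 subtype (Homo sapiens), read by radioligand binding (a lower number here means a stronger inhibitor, a higher number a weaker inhibitor), compound 1 gives 12 nM, which is the second highest of the three numbers. Compound 2 gives 9.1 nM, and compound 3 gives 15 nM. Every step among them stays within the scatter: a 1.3-fold lower number from compound 1 to compound 2 (0.12 log units; within the scatter), a 1.3-fold higher number from compound 1 to compound 3 (0.10 log units; within the scatter), and a 1.6-fold higher number from compound 2 to compound 3 (0.22 log units; within the scatter).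

Compound 4, `CC(C)C(Cc1nnn[nH]1)c1ccc(-c2ccc3cccc(F)c3c2)[nH]c1=O`, is not yet measured. It differs from compound 1 in that ((1H-tetrazol-5-yl)methyl in place of 4H-1,2,4-triazol-3-yl on a saturated chain carbon bound to an aromatic carbon and a saturated chain carbon). The measured steps from compound 1 to compound 2 and to compound 3 bear on this change, since each swaps the five-membered ring group at the same place; both were within the scatter. Within the data shown here, no measured step shows the effect of adding a methylene between the chain carbon and the ring, so that part is untested. Compound 4 is therefore expected to land close to compound 1, with a 1.3-fold higher number from compound 1 to compound 4 (0.12 log units; within the scatter) as the estimated step in this assay. For compound 4 the estimate is 16 nM, with a range from 5 nM to 50 nM.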

Compound 4, inhibition constant: 34 nM
Estimate against measurement, compound 4: 2.1-fold (0.33 log units) below; the measured number falls inside the stated range.
By their numbers in this assay, from the lowest: compounds 2, 1 and 3 (each within the scatter of the next); then compound 4.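

In this assay, among these compounds, the group on this saturated chain carbon does matter: (1H-tetrazol-5-yl)methyl is the only one of the four groups whose steps to all the others lie beyond the scatter, with a 2.8-fold higher number from compound 1 to compound 4 (0.45 log units; beyond the scatter), a 2.3-fold higher number from compound 3 to compound 4 (0.36 log units; beyond the scatter) and a 3.7-fold higher number from compound 2 to compound 4 (0.57 log units; beyond the scatter). These steps are modest, and because the change from compound 1 to compound 4 alters the ring and adds a methylene together, it cannot show which of the two accounts for the higher number. Nothing available explains this rise.

Still open, from the compounds shown here alone, is how 1H-tetrazol-5-yl without the methylene, or (4H-1,2,4-triazol-3-yl)methyl, would compare, and either would help separate the ring from the added carbon. Also open, going by these compounds, is how a carboxylic acid or a longer chain ending in the tetrazole would fare at this place.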